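The source may report more compounds than this note shows. Statements on the series, on what has been measured and on what is new or still open speak of the compounds shown alone.

Series notes. The shared core of compound 3 `CCCn1c(=O)[nH]c2nc(-c3ccc(S(=O)(=O)N4CCN(Cc5ccc(Br)c(F)c5)CC4)cc3)[nH]c2c1=O` carries a ring amine nitrogen bearing a 4-bromo-3-fluorobenzyl group. In an assay on CHO cells for displacement of a labelled ligand from adenosine receptor A3 (Homo sapiens), read by scintillation counting, with a stated time of 45 min, tested at 1 uM, in the presence of a further agent that is not named here (on this read-out higher numbers stand for more inhibition at the one concentration tested (going by the name of the read-out) and lower numbers for less inhibition), compound 3 gives 27%. Compound 2 `CCCn1c(=O)[nH]c2nc(-c3ccc(S(=O)(=O)N4CCN(c5cccc(Br)c5)CC4)cc3)[nH]c2c1=O`, with 3-bromophenyl on the same ring nitrogen, gives in this assay 27%; no change at the digits printed from compound 2 to compound 3 (within the scatter). Compound 1 `CCCn1c(=O)[nH]c2nc(-c3ccc(S(=O)(=O)N4CCN(Cc5cccc(C)c5)CC4)cc3)[nH]c2c1=O`, with 3-methylbenzyl there, gives in this assay 17%, so that a number 10 percentage points higher from compound 1 to compound 3 (within the scatter) and a number 10 percentage points higher from compound 1 to compound 2 (within the scatter). Within the data shown here, compound 3 thus stands level with compound 2, the two together the highest of the three numbers, while no step among the three goes beyond the scatter.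

Compound 4 `CCCn1c(=O)[nH]c2nc(-c3ccc(S(=O)(=O)N4CCN(c5ccccc5)CC4)cc3)[nH]c2c1=O` differs from compound 3 in one place: phenyl in place of 4-bromo-3-fluorobenzyl on an amine nitrogen in a ring. Among the measured compounds shown here, the steps that bear on this are the exchange of a benzyl-type group for a phenyl-type group on the ring nitrogen in a number 10 percentage points higher from compound 1 to compound 2 (within the scatter) and the reverse exchange in no change at the digits printed from compound 2 to compound 3 (within the scatter), neither of them beyond the scatter. For compound 4 the expected step is therefore a number 4 percentage points lower from compound 3 to compound 4 (within the scatter), nothing beyond the scatter in either direction. The estimate for compound 4 in this assay is 23%, with a range from 5% to 42%.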

Compound 4, a percentage reported as inhibition, at one concentration (the size of the read-out at that concentration, not a potency): 27%
Compound 4: middle estimate off by 4 percentage points, on the low side, within the range that was stated.
By their numbers in this assay, from the lowest: compounds 1, 2, 3 and 4 (each within the scatter of the next).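

In this assay, phenyl in place of 4-bromo-3-fluorobenzyl on the ring amine nitrogen, with 6 heavy atoms where there were 9 and without the fluorine and the bromine, brings no change at the digits printed from compound 3 to compound 4 (within the scatter), so the number with the bare phenyl is level with the number with the larger substituted group within this set. Hydrogen in place of bromo on an aromatic carbon is the first exchange here confined to the aromatic substituent, and it brings no change at the digits printed from compound 2 to compound 4 (within the scatter), while phenyl in place of 3-methylbenzyl brings a number 10 percentage points higher from compound 1 to compound 4 (within the scatter), so every step at this position among the four compounds stays inside the scatter. No measurement to hand offers any explanation for this flat picture at the ring nitrogen.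

On these data alone, what a carboxylic acid, a primary amine or a longer chain such as phenylethyl on this ring nitrogen would do in this assay remains open. Also open, as far as these compounds go, is whether any group at this position can move the number beyond the scatter, and how these single-concentration readings relate to potency.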